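This account rests on a few compounds, and the source may have more. Where it says the series, first, only, none or still open, it means among the compounds named here.

Measured compounds:
compound 1 `C[C@@H]1CN(C(=O)OC(C)(C)C)CCN1c1ncc(OCc2ccc(S(=O)(=O)N(C)C)cc2)cn1`, a functional assay for agonist activity at Glucose-dependent insulinotropic receptor (Mus musculus), read by HTRF and cAMP accumulation, with a stated time of 45 min (on this read-out lower numbers stand for an effect already at smaller amounts and higher numbers for an effect only at larger amounts of compound), 264 nM
compound 2 `C[C@@H]1CN(C(=O)OC(C)(C)C)CCN1c1ncc(OCc2ccc(C#N)cc2)cn1`, 148 nM
compound 3 `COc1cnccc1COc1cnc(N2CCN(C(=O)OC(C)(C)C)CC2)nc1`, 71 nM

Compound 2 stands second highest of the three numbers in this assay. Going by the values given here, its nearest neighbour is compound 1, at 264 nM, and the only single-point step in the set runs between them: a 1.8-fold lower number from compound 1 to compound 2 (0.25 log units; within the scatter). Compound 3 is the furthest from it, at 71 nM, a gap that lies beyond the scatter; compound 3 differs from compound 2 in more than one place, so no step is shown for that pair and only the two values speak.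

Compound 4 `Cc1cnccc1COc1cnc(N2CCN(C(=O)OC(C)(C)C)C[C@H]2C)nc1` has not been measured. From compound 2 it differs by 3-methylpyridin-4-yl in place of 4-cyanophenyl on a saturated chain carbon bound to an oxygen on an aromatic ring. Among the compounds with values here, the one measured step, from compound 1 to compound 2, exchanges a group at the same place but neither of its groups is the one entering here, so it bears on this step only loosely and was itself within the scatter. Compound 3, which carries a pyridinyl methoxy group of a related kind, gives the lowest number in the set, but its second difference from compound 2 keeps that from being a clean guide.

The expectation for compound 4 is a modest move toward lower numbers, a 1.9-fold lower number from compound 2 to compound 4 (0.27 log units; within the scatter), with a wide range: compound 4 is estimated at 80 nM, between 30 nM and 220 nM.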

Compound 4, half-maximal effective concentration: 236 nM
The estimate for compound 4 lay 3.0-fold (0.47 log units) below the measured number; measured number above the stated range.
By their numbers in this assay, from the lowest: compound 3; then compounds 2, 4 and 1 (each within the scatter of the next).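

In this assay, the exchange on a saturated chain carbon bound to an oxygen on an aromatic ring now extends to a ring with a hetero atom: 3-methylpyridin-4-yl in place of 4-cyanophenyl gives a 1.6-fold higher number from compound 2 to compound 4 (0.20 log units; within the scatter). Together with a 1.8-fold lower number from compound 1 to compound 2 (0.25 log units; within the scatter), this makes two exchanges at this place, and neither separates its two compounds beyond the scatter, so the pyridine ring of compound 4 brings no measurable change from the 4-cyanophenyl group of compound 2. The value of compound 3, 71 nM, therefore cannot be credited to a pyridinyl methoxy group as such, and no measurement is available to explain the result.

Compound 3 differs from compound 2 and compound 4 in more than one place, so the compounds shown leave open which of its differences goes with its value. Also open, as far as these compounds go, is how this position responds when the methyl group of 3-methylpyridin-4-yl is replaced by an amine, a carboxylic acid or a longer chain such as propyl.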